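Aryl swap on compound 1: expected effect on cytotoxicity

The source may report more compounds than this note shows. Statements on the series, on what has been measured and on what is new or still open speak of the compounds shown alone.

Measured so far:
compound 1, `COc1cc(OC)c(C(=O)/C=C/c2cccc(F)c2)c(O)c1CC=C(C)C` — 45400 nM
compound 2, `CCCCCc1c(OC)cc(OC)c(C(=O)/C=C/c2cccc(N3CCNCC3)c2)c1O` — > 100000 nM

Within the data shown here, in an ADME assay on MCF7-DOX cells (Homo sapiens) for cytotoxicity, read by MTT assay, with a stated time of 48 h (on this read-out lower numbers stand for stronger inhibition and higher numbers for weaker inhibition), compound 1 gives 45400 nM and is the only compound with a numerical value. Compound 2 reaches only a limit of the assay, > 100000 nM, so it is not a number and gives no size of difference to compound 1; the limit of > 100000 nM in this assay, at which 1 of the 2 values shown sits, holds for it. Among the measured compounds shown here, no pair of measured compounds differs in one place, so no measured step is available.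

Compound 3, `COc1cc(OC)c(C(=O)/C=C/c2ccc(N(C)C)cc2)c(O)c1CC=C(C)C`, has not been measured in this assay. It differs from compound 1 as follows: 4-(dimethylamino)phenyl in place of 3-fluorophenyl on a double-bonded chain carbon bound to a double-bonded chain carbon. For the measured compounds named here, with no measured step to rest on, the expectation is guided by compound 1 alone. The step expected is a 1.8-fold lower number from compound 1 to compound 3 (0.26 log units; within the scatter), a modest change toward stronger inhibition that may still fall inside the usual scatter. For compound 3 the estimated value in this assay is 25000 nM, with a range from 7000 nM to 90000 nM.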

Compound 3, half-maximal inhibitory concentration: > 100000 nM
Compound 3 was reported as a limit; the forecaster's own chance of this, stated with the estimate: 20%; middle value at least 4.0-fold (0.60 log units) from the limit.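

Working from the core of compound 1, the aryl group on a double-bonded chain carbon bound to a double-bonded chain carbon now has its first readable step in this assay: replacing 3-fluorophenyl with 4-(dimethylamino)phenyl gives an at least 2.2-fold higher number from compound 1 to compound 3 (0.34 log units; beyond the scatter), a change toward weaker inhibition. This position is therefore not indifferent to the aryl group, and of the two groups compared on this core, only 3-fluorophenyl gives a numerical value. Compound 3 gives > 100000 nM, which is a limit of the assay and not a number, so the step has a lower bound but no known full size: the limit of > 100000 nM in this assay, at which 2 of the 3 values shown sit.

The swap changes both the substituent and its printed place on the aryl group, so the compounds shown do not separate the contribution of the dimethylamino group from that of its location. From the compounds shown here alone, whether 4-fluorophenyl, 3-(dimethylamino)phenyl or a phenyl group bearing a carboxylic acid would give a numerical value on this core in this assay remains open.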